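Chloro Substitution on a Second Sulfonyl-Indole Core

The source may hold more compounds than are shown below. What is called first, only, known or untested is meant among the compounds shown, and "the series" means these compounds.

Three tetrahydropyridinyl indole sulfonamides have been characterised in an assay on HEK293 cells for displacement of a labelled ligand from 5-hydroxytryptamine receptor 6 (Homo sapiens), read by scintillation counting; on this read-out lower numbers stand for stronger inhibition and higher numbers for weaker inhibition. Compound 2 `O=S(=O)(c1cncc2ccccc12)n1cc(C2=CCNCC2)c2ccccc21` gives 5 nM, and compound 1 `O=S(=O)(c1cnc2ccccc2c1)n1cc(C2=CCNCC2)c2ccccc21` gives 13 nM; the difference between the two cores is not broken down here. Compound 3 `O=S(=O)(c1cncc2ccccc12)n1cc(C2=CCNCC2)c2cc(Cl)ccc21` carries a chlorine on the core of compound 2. In this assay compound 3 gives 18 nM. The change from compound 2 to compound 3 is chloro in place of hydrogen on an aromatic carbon and produced a 3.6-fold higher number from compound 2 to compound 3 (0.56 log units; beyond the scatter).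

Compound 4 `O=S(=O)(c1cnc2ccccc2c1)n1cc(C2=CCNCC2)c2ccc(Cl)cc21` remains to be measured in this assay. It arises from compound 1 by chloro in place of hydrogen on an aromatic carbon, the same change, made at a place described in the same words, that turned compound 2 into compound 3. Among the measured compounds shown here, because the only precedent is a 3.6-fold higher number from compound 2 to compound 3 (0.56 log units; beyond the scatter), the account expects a step of similar size on the core of compound 1, namely a 3.1-fold higher number from compound 1 to compound 4 (0.49 log units; beyond the scatter), while allowing that a single example is a thin basis and the second core may respond somewhat differently. On that footing compound 4 is estimated at 40 nM, with a range from 15 nM to 110 nM.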

Compound 4, inhibition constant: 37 nM
Compound 4: middle estimate off by 1.1-fold (0.03 log units), on the high side; measured number inside the range.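

In this assay chloro in place of hydrogen on an aromatic carbon gives a 2.8-fold higher number from compound 1 to compound 4 (0.45 log units; beyond the scatter) on this second core, so the number rises on both cores shown. The two steps agree within the scatter: the same change on two cores in this assay, a 3.6-fold higher number (0.56 log units; beyond the scatter) from compound 2 to compound 3 and a 2.8-fold higher number (0.45 log units; beyond the scatter) from compound 1 to compound 4, 1.3-fold (0.10 log units) apart, within the scatter of two such steps. Among the compounds shown here, this is still only two cases of one change, and it does not show that the step would carry to any further core; the place reads the same in words, meta to a fused ring and para to a fused ring, but the two structures carry the chloro on different carbons of that ring, so core and carbon change together between the two steps.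

The compounds shown leave open whether chloro on the other carbon would give a similar step on each core. They also leave open whether another group on these carbons, such as fluoro, methoxy or a nitrile, would move the number as chloro does.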